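The source may report more compounds than this note shows. Statements on the series, on what has been measured and on what is new or still open speak of the compounds shown alone.

Three compounds of one shared core, all carrying a substituted amine on that core, have been tested in a functional assay on K562 cells (Homo sapiens) for cytotoxicity, read by MTT assay, with a stated time of 72 h; a higher number here means a weaker inhibitor, a lower number a stronger inhibitor. Compound 1 `COc1ccc2c(c1)[n+]([O-])nc(NCOC(C)c1ccccc1)[n+]2[O-]` gives 6690 nM, compound 3 `O=[N+]([O-])c1cccc(COCNc2n[n+]([O-])c3ccccc3[n+]2[O-])c1` gives 5650 nM, and compound 2 `[O-][n+]1nc(NCOC2CCCCC2)[n+]([O-])c2ccccc21` gives 10800 nM. In this assay compound 2 sits within the usual scatter of both compound 1 and compound 3, so the three numbers cannot be told apart. Compound 4 `CCCOCNc1n[n+]([O-])c2ccccc2[n+]1[O-]` has not yet been measured; it differs from compound 2 in one place: propyl in place of cyclohexyl on an oxygen on a saturated carbon. For the measured compounds named here, no step between measured compounds bears on this change, so the step is expected to be no larger than the scatter, as a 1.2-fold lower number from compound 2 to compound 4 (0.08 log units; within the scatter). The estimate for compound 4 in this assay is 9000 nM, with a range from 4000 nM to 20000 nM.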

Compound 4, half-maximal inhibitory concentration: 17600 nM
For compound 4 the middle estimate is 2.0-fold (0.29 log units) below the measured one, within the range that was stated.
By their numbers in this assay, from the lowest: compounds 3, 1, 2 and 4 (each within the scatter of the next, the first and the last beyond it).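

In this assay, for the compounds shown here, the exchange at this position gives a 1.6-fold higher number from compound 2 to compound 4 (0.21 log units; within the scatter) and so is the first direct reading of a change on this oxygen. It shows that an open propyl chain can stand in place of the cyclohexyl ring, with fewer carbons, without a step that clears the scatter. Nothing available explains this result. The compounds shown leave open whether a longer chain such as octyl, or an unsubstituted benzyl group, on this oxygen would move the number beyond the scatter.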